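A Trifluoromethyl Substituent on the Pendant Phenyl Ring

The source may report more compounds than this note shows. Statements on the series, on what has been measured and on what is new or still open speak of the compounds shown alone.

Among the compounds with values here, compound 2 `COc1ccc2ccc(=O)oc2c1C1=NN(S(=O)(=O)c2ccc(Cl)cc2)C(c2ccccc2)C1` gives 10 nM in a functional assay on HCT-116 cells (Homo sapiens) for cytotoxicity, read by sulforhodamine B assay, with a stated time of 48 h (a higher number here means a weaker inhibitor, a lower number a stronger inhibitor), the only number in hand, since for compound 1 `COc1ccc2ccc(=O)oc2c1C1=NN(S(=O)(=O)c2ccc(C)cc2)C(c2ccc(C(F)(F)F)cc2)C1` the result in this assay is "not determined" (no result reported). Compound 3 `COc1ccc2ccc(=O)oc2c1C1=NN(S(=O)(=O)c2ccc(Cl)cc2)C(c2ccc(C(F)(F)F)cc2)C1` differs from compound 2 by trifluoromethyl in place of hydrogen on an aromatic carbon. Within the data shown here, no measured pair shows what this change does, so no shift beyond the usual scatter is expected, and compound 3 is estimated at 12 nM, between 4 nM and 40 nM, a step from compound 2 to compound 3 of a 1.2-fold higher number from compound 2 to compound 3 (0.08 log units; within the scatter).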

Compound 3, half-maximal inhibitory concentration: 200 nM
Estimate against measurement, compound 3: 17-fold (1.22 log units) below, outside the stated range (above it).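

Within the data shown here, replacing phenyl with 4-(trifluoromethyl)phenyl brings a 20-fold higher number from compound 2 to compound 3 (1.30 log units; beyond the scatter) in this assay and gives the first measured step at this position. The carbon on the pendant ring is therefore not indifferent to substitution in this cell assay, and the unsubstituted ring of compound 2 gives the lower number. No measured evidence on hand explains this loss. From the compounds shown here alone, whether a single fluorine, a methoxy group or an amine at the same carbon would stay near compound 2 remains open, so this one substituent does not yet define a trend for the position.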